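Swapping the Amide Substituent from Cyclohexyl to Pyrrolidine

The compounds below may be only part of what the source reports. "The series", "measured", "known", "first", "only" and "open" are said of these compounds alone.

Of the compounds shown here, two sharing one core have been measured in a functional assay on HepG2 cells (Homo sapiens) for antiproliferative activity, read by CCK-8 assay, with a stated time of 48 h; on this read-out lower numbers stand for stronger inhibition and higher numbers for weaker inhibition. Compound 1 `O=C(NCc1ccccc1)c1cc(Oc2ccc(/C=C/c3ccncc3)cc2)ccn1` gives 28900 nM, and compound 2 `O=C(NC1CCCCC1)c1cc(Oc2ccc(/C=C/c3ccncc3)cc2)ccn1` gives 22400 nM. Compound 2 stands at one end of two numbers that the scatter does not separate, as a 1.3-fold lower number from compound 1 to compound 2 (0.11 log units; within the scatter) shows. Compound 3 `O=C(c1cc(Oc2ccc(/C=C/c3ccncc3)cc2)ccn1)N1CCCC1` differs from compound 2 by pyrrolidin-1-yl in place of cyclohexylamino on a carbonyl carbon. For the measured compounds named here, the only measured step, a 1.3-fold lower number from compound 1 to compound 2 (0.11 log units; within the scatter), also changed the group on the amide and hardly moved the number, so no step beyond the scatter is expected in no change at the digits printed from compound 2 to compound 3 (within the scatter). Compound 3 is therefore estimated at 22400 nM, with a range from 8000 nM to 60000 nM.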

Compound 3, half-maximal inhibitory concentration: 41600 nM
The estimate for compound 3 lay 1.9-fold (0.27 log units) below the measured number, within the range that was stated.
By their numbers in this assay, from the lowest: compounds 2, 1 and 3 (each within the scatter of the next).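

In this assay pyrrolidin-1-yl on this carbonyl carbon carries no hydrogen-bond donor, unlike cyclohexylamino and benzylamino, and the two steps to it read (a 1.9-fold higher number from compound 2 to compound 3 (0.27 log units; within the scatter)) and (a 1.4-fold higher number from compound 1 to compound 3 (0.16 log units; within the scatter)). Losing the amide hydrogen and closing the ring onto the nitrogen therefore gives no step beyond the scatter in these compounds. No measurement shown accounts for these numbers. Going by these compounds, it remains open whether an amine, a carboxylic acid or a longer chain at this place would stand clear of the scatter. On these data alone, the shared core, which stays the same in all three compounds, remains untested by these steps.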